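The compounds below may be only part of what the source reports. "The series", "measured", "known", "first", "only" and "open" are said of these compounds alone.

Series notes. Going by the values given here, compound 1 `NC(=O)Cn1c(=O)n(C2OC(CO)[C@@H](O)[C@H]2O)c2nc(N)nc(O)c21` gives 190 uM in a functional assay (B cells) with Mus musculus as the target (on this read-out lower numbers stand for an effect already at smaller amounts and higher numbers for an effect only at larger amounts of compound), and stands highest of the two numbers measured so far; compound 2 `C=CCn1c(=O)n([C@H]2CO[C@@H](CO)C2)c2nc(N)nc(O)c21` gives 83 uM in this assay, and the gap between these two values lies beyond the scatter. Compound 3 `[N-]=[N+]=NCC(O)Cn1c(=O)n(C2OC(CO)[C@@H](O)[C@H]2O)c2nc(N)nc(O)c21` is not yet measured and differs from compound 1 in one place: 2-azido-1-hydroxyethyl in place of carbamoyl on a saturated chain carbon bound to an aromatic nitrogen. Among the compounds with values here, no step between measured compounds covers this change, so the expected step is small, a 1.2-fold lower number from compound 1 to compound 3 (0.07 log units; within the scatter), and is expected to stay within the scatter in either direction. For compound 3 the estimate in this assay is 160 uM, with a range from 60 uM to 400 uM.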

Compound 3, concentration for half-maximal effect: 39 uM
Compound 3: the middle estimate sits 4.1-fold (0.61 log units) above what was measured; the measured number lies below the stated range.
By their numbers in this assay, from the lowest: compound 3; then compound 2; then compound 1.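

In this assay, the substituent on this saturated chain carbon bound to an aromatic nitrogen clearly affects the read-out: 2-azido-1-hydroxyethyl in place of carbamoyl gives a 4.9-fold lower number from compound 1 to compound 3 (0.69 log units; beyond the scatter). In this single pair, the carbamoyl is therefore not needed for the effect, and the larger group gives the lower number. No available data explain the step. The compounds shown leave open whether the azido group or the hydroxyl carries the step. They also leave open how a plain propyl chain, an amine or a carboxylic acid would read at this position.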